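The source may hold more compounds than are shown below. What is called first, only, known or untested is meant among the compounds shown, and "the series" means these compounds.

Compound 2 `COc1cc(C2CC(=NOC(=O)c3ccc(Br)cc3)CC(c3ccc(O)c(OC)c3)N2C)ccc1O` was measured in a functional assay, read by spectrophotometry, with a stated time of 30 min (on this read-out higher numbers stand for weaker inhibition and lower numbers for stronger inhibition), and gave 108000 nM. Its number sits at the low end of the three recorded, though the gaps to both neighbours are within the scatter: compound 1 `COc1cc(C2CC(=NOC(=O)c3ccc(Cl)cc3)CC(c3ccc(O)c(OC)c3)N2C)ccc1O` gave 112000 nM in this assay, and compound 3 `COc1cc(C2CC(=NOC(=O)c3ccc(F)cc3)CC(c3ccc(O)c(OC)c3)N2C)ccc1O` gave 141000 nM. The measured steps bear this out: a 1.0-fold lower number from compound 1 to compound 2 (0.02 log units; within the scatter), a 1.3-fold higher number from compound 1 to compound 3 (0.10 log units; within the scatter) and a 1.3-fold higher number from compound 2 to compound 3 (0.12 log units; within the scatter). Swapping one halogen for another on this aromatic carbon has thus left the read-out unchanged within the scatter across all three compounds.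

Compound 4 `COc1cc(C2CC(=NOC(=O)c3ccc([N+](=O)[O-])cc3)CC(c3ccc(O)c(OC)c3)N2C)ccc1O` has not yet been measured. It differs from compound 2 in one place: nitro in place of bromo on an aromatic carbon. Among the compounds with values here, no measured step introduces a nitro group, so the halogen swaps are the only guide, and they all stayed within the scatter. On that basis, compound 4 is expected to stay close to compound 2, with the step in this assay estimated as a 1.0-fold higher number from compound 2 to compound 4 (0.01 log units; within the scatter), giving no movement beyond the scatter in either direction. Within the data shown here, compound 4 is therefore estimated at 110000 nM in this assay, with a range from 50000 nM to 240000 nM, the range widened because no measured step covers this kind of change.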

Compound 4, half-maximal inhibitory concentration: 79000 nM
Compound 4: middle estimate off by 1.4-fold (0.14 log units), on the high side, within the range that was stated.
By their numbers in this assay, from the lowest: compounds 4, 2, 1 and 3 (each within the scatter of the next).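

In this assay, nitro in place of a halogen on this aromatic carbon, para to a large group, gives a 1.4-fold lower number from compound 2 to compound 4 (0.14 log units; within the scatter), a 1.4-fold lower number from compound 1 to compound 4 (0.15 log units; within the scatter) and a 1.8-fold lower number from compound 3 to compound 4 (0.25 log units; within the scatter), so the read-out stays within the scatter even for a group that is not a halogen. Until now, only swaps of one halogen for another had been seen at this position, whereas this change brings in 3 heavy atoms and 2 hydrogen-bond acceptors where bromo has 1 heavy atom and 0 hydrogen-bond acceptors, and that difference in make-up does not carry the number beyond the scatter. The information at hand offers no measurement that would explain why these four compounds read so much alike.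

The compounds shown leave open whether an amine, a carboxylic acid or a longer alkyl chain on this aromatic carbon would move the number beyond the scatter in either direction. Since all four compounds differ only at this one carbon, they also leave open whether an amide in place of the carbonyl-oxy link, or any change to the shared core, would shift the read-out.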